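Dropping the trifluoromethyl group: expected cytotoxicity of compound 4

This account rests on a few compounds, and the source may have more. Where it says the series, first, only, none or still open, it means among the compounds named here.

Compound 1 `COc1cccc(-c2cc(C(F)(F)F)c3c(N)c(C(N)=O)sc3n2)c1`: in an ADME assay on Huh-7 cells (Homo sapiens) for cytotoxicity, read by MTT assay, with a stated time of 72 h (on this read-out higher numbers stand for lower toxicity in this test and lower numbers for higher toxicity in this test), compound 1 gives > 20000 nM, which is a limit of the assay rather than a number.
Compound 2 `COc1ccccc1-c1cc(C(F)(F)F)c2c(N)c(C(N)=O)sc2n1`: in this assay compound 2 gives > 20000 nM, again a limit.
Compound 3 `NC(=O)c1sc2nc(C3CC3)cc(C(F)(F)F)c2c1N`: in this assay compound 3 gives > 20000 nM, also a limit.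

Compound 2 therefore stands exactly where the other two stand, at the limit of > 20000 nM in this assay, at which 3 of the 3 values shown sit. Every value is a limit. The measured steps therefore cannot be sized: a step that the two limits leave unreadable from compound 1 to compound 2, a step that the two limits leave unreadable from compound 1 to compound 3 and a step that the two limits leave unreadable from compound 2 to compound 3. What they do show is that swapping the group on the shared core, whether an aryl ring or a cyclopropyl, never pushed toxicity into the measurable range.

Compound 4 `COc1ccccc1-c1ccc2c(N)c(C(N)=O)sc2n1` differs from compound 2 by hydrogen in place of trifluoromethyl on an aromatic carbon. Among the measured compounds shown here, no measured step touches this group, so there is no direct guide; the only available evidence is that three different compounds on this core all sit at the limit. The expected step is a step that the limit leaves unreadable from compound 2 to compound 4, meaning no change beyond the scatter. Compound 4 is expected to give 25000 nM, with a range from 10000 nM to 60000 nM, most likely reported again as a limit.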

Compound 4, half-maximal cytotoxic concentration: > 20000 nM
Compound 4: a limit, no number; the forecaster's own chance of this, stated with the estimate: 80%; the middle value is on the limit's open side.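

Among the compounds shown here, compound 2 and compound 4 both give a limit rather than a number in this assay so no step between them can be read: the limit of > 20000 nM in this assay, at which 4 of the 4 values shown sit. The compounds shown leave open at what concentration any of them would become toxic to these cells, and whether any change on the shared core would bring toxicity into the measurable range.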